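Tolerance of compound 3 in MT4 cells

A few compounds are considered here, and "the series" means these few. Any claim that something is new, unique, unknown or untested is made for them only; others in the source may bear on it.

Measured in an ADME assay on MT4 cells (Homo sapiens) for cytotoxicity, read by MTT assay; a lower number here means that less compound is tolerated, a higher number that more compound is tolerated:
- compound 1 `Cc1cc(C)cc(S(=O)(=O)c2c(C(=O)NCC(=O)NCc3ccncc3)[nH]c3ccc(Cl)cc23)c1`: > 48900 nM (a limit)
- compound 2 `Cc1cc(C)cc(S(=O)(=O)c2c(C(=O)NCc3cccc(N)c3)[nH]c3ccc(Cl)cc23)c1`: > 53400 nM (a limit)

Compound 2 stands only at a limit, > 53400 nM. In compound 3 `Cc1cc(C)cc(S(=O)(=O)c2c(C(=O)NCC(=O)NC(C)c3ccccc3F)[nH]c3ccc(Cl)cc23)c1`, (1-(2-fluorophenyl)ethyl)carbamoyl takes the place of 3-aminophenyl on a saturated chain carbon bound to an amide-type nitrogen: (1-(2-fluorophenyl)ethyl)carbamoyl in place of 3-aminophenyl on a saturated chain carbon bound to an amide-type nitrogen. Among the measured compounds shown here, the one measured step bearing on this, a step that the two limits leave unreadable from compound 1 to compound 2, gives no size. Compound 1, with ((pyridin-4-yl)methyl)carbamoyl at that place, also reads only as a limit, > 48900 nM. No step beyond the scatter is therefore expected in this assay, and the expected change is an at least 1.2-fold lower number from compound 2 to compound 3 (0.10 log units; that floor lies within the scatter). For compound 3 the estimate is 42000 nM, with an expected range of 15000 nM to 60000 nM.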

Compound 3, half-maximal cytotoxic concentration: 23000 nM
Beside the measured number, compound 3's estimate is 1.8-fold (0.26 log units) above it; low and high end bracket the measured number.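

In this assay, among the compounds shown here, compound 3 is the only compound of the three that gives a number rather than a limit, so this place on a saturated chain carbon bound to an amide-type nitrogen now shows a readable change. The entry of (1-(2-fluorophenyl)ethyl)carbamoyl gives an at least 2.3-fold lower number from compound 2 to compound 3 (0.36 log units; beyond the scatter) as a floor on the true size. On the amide-type nitrogen, 1-(2-fluorophenyl)ethyl in place of (pyridin-4-yl)methyl gives an at least 2.1-fold lower number from compound 1 to compound 3 (0.32 log units; beyond the scatter) as a floor too. The compounds shown leave open whether the fluorine or the branching methyl carries this change, and what a carboxylic acid or a longer chain would give there.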